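Shifting the pyridine attachment point

The source may hold more compounds than are shown below. What is called first, only, known or untested is meant among the compounds shown, and "the series" means these compounds.

Of the compounds shown here, three sharing one core have been tested in a functional assay on MV4-11 cells (Homo sapiens) for antiproliferative activity, with a stated time of 6 days, tested at 6.25 uM; a higher number here means a stronger effect of the compound at the concentration tested, a lower number a weaker effect. Compound 1 `CNC(=O)N1CCCc2ccc(NC(=O)c3ccc(-c4ccncc4)cc3)cc21` gives 88.7% in this assay, the highest of the three. Compound 3 `CNC(=O)N1CCCc2ccc(NC(=O)c3ccccc3-c3ccccc3)cc21` gives 60.4%, and compound 2 `CNC(=O)N1CCCc2ccc(NC(=O)c3cccc(-c4cnn(S(C)(=O)=O)c4)c3)cc21` gives 18%; both gaps to compound 1 lie beyond the scatter, so compound 1 is the strongest of the set. The next compound, compound 4 `CNC(=O)N1CCCc2ccc(NC(=O)c3ccc(-c4cccnc4)cc3)cc21`, differs from compound 1 in one place: pyridin-3-yl in place of pyridin-4-yl on an aromatic carbon. Within the data shown here, no measured pair in the set isolates this change, so no step is known for it. The three measured values show that the group attached to this ring matters, with compound 1 and compound 2 far apart, but the two pyridyl variants are not separated by any measured pair. A modest loss is expected for compound 4, with the step of a number 12.7 percentage points lower from compound 1 to compound 4 (beyond the scatter) likely small relative to the spread already seen, though a fall beyond the scatter cannot be ruled out. Compound 4 is therefore estimated at 76% in this assay, within 45% to 92%.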

Compound 4, a percentage reported as inhibition, at one concentration (the size of the read-out at that concentration, not a potency): 92.1%
The estimate for compound 4 lay 16.1 percentage points below the measured number, outside the stated range (above it).
By their numbers in this assay, from the lowest: compound 2; then compound 3; then compounds 1 and 4 (each within the scatter of the next).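

In this assay, pyridin-3-yl in place of pyridin-4-yl, on an aromatic carbon para to a large group, gives a number 3.4 percentage points higher from compound 1 to compound 4 (within the scatter), the only step shown at this position. Within this pair, the read-out does not separate the two pyridyl attachments: compound 1 gives 88.7% and compound 4 gives 92.1%, so the change costs nothing detectable at the single concentration tested. No evidence on any property of these compounds bears on this result.

From the compounds shown here alone, since this is a read-out at one concentration, whether compound 1 and compound 4 differ in potency stays open. Also open, going by these compounds, is whether the ring nitrogen matters at all, which a plain phenyl ring at this position would test, and how an amine or a carboxylic acid on that ring would fare.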